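The source may hold more compounds than are shown below. What is called first, only, known or untested is meant among the compounds shown, and "the series" means these compounds.

Measured so far:
compound 1 `COC(=O)Nc1cc(-c2ccc(OC[C@@](C)(N)CC(C)C)cn2)ccn1`: 23 nM
compound 2 `COC(=O)Nc1cc(-c2ccc(OC[C@@](C)(N)CC(C)C)c(Cl)n2)ccn1`: 0.5 nM
compound 3 `CC(C)C[C@H](N)COc1ccc(-c2ccnc(NCc3ccccc3)c2)cc1`: 127 nM

Among these three compounds in an assay on isolated protein for inhibition of AP2-associated protein kinase 1 (Homo sapiens), with a stated time of 3 h, in the presence of a further agent that is not named here (a lower number here means a stronger inhibitor, a higher number a weaker inhibitor), compound 1 stands second highest: compound 2 gives the lowest number and compound 3 the highest, and both steps separating them from compound 1 lie beyond the scatter. Compound 4 `COC(=O)Nc1cc(-c2cc(C)c(OC[C@@](C)(N)CC(C)C)cn2)ccn1` is compound 1 with a single alteration: methyl in place of hydrogen on an aromatic carbon. Within the data shown here, only one measured step changes the same ring of compound 1, a 46-fold lower number from compound 1 to compound 2 (1.66 log units; beyond the scatter). That step was large, but it concerns a chloro rather than a methyl, entering elsewhere on that ring, so it sets no direct expectation for the methyl of compound 4; compound 3 differs from compound 1 in several places at once and offers no guidance either. Among the measured compounds shown here, with no matching precedent, a step in this assay close to the scatter, in either direction, is the safest expectation. For compound 4 the expected step is a 1.5-fold lower number from compound 1 to compound 4 (0.19 log units; within the scatter), giving an estimated value of 15 nM, within a range from 4 nM to 60 nM.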

Compound 4, half-maximal inhibitory concentration: 1.7 nM
Beside the measured number, compound 4's estimate is 8.8-fold (0.95 log units) above it; measured number below the stated range.
By their numbers in this assay, from the lowest: compound 2; then compound 4; then compound 1; then compound 3.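

In this assay, the carbon opposite the ring nitrogen and ortho to the (2-amino-2,4-dimethylpentyl)oxy group proves highly sensitive to substitution: adding a methyl, only one heavy atom, gives a large step (a 14-fold lower number from compound 1 to compound 4 (1.13 log units; beyond the scatter)). Among these compounds, the only earlier large change on this ring was a chloro at a different place (a 46-fold lower number from compound 1 to compound 2 (1.66 log units; beyond the scatter)), so two separate single additions to the ring of compound 1 have now each lowered the number well beyond the scatter. Nothing measured here explains the effect of the methyl.

As far as these compounds go, whether an ethyl, a methoxy or a chloro at this same carbon would also lower the number remains open, so it is unclear how specific the result is to methyl. It is also unknown whether this methyl and the chloro of compound 2 would add up in a single molecule.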